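A Second Chloro on the Fused Ring of Compound 1

A few compounds are considered here, and "the series" means these few. Any claim that something is new, unique, unknown or untested is made for them only; others in the source may bear on it.

Compound 1 `CC#C[C@@H](CC(=O)O)c1ccc(OC[C@H]2COc3cc(Cl)ccc3O2)cc1` is tested in a functional assay on HEK293 cells for agonist activity at Free fatty acid receptor 1 (Homo sapiens), read by fluorescence and calcium flux, with a stated time of 10 min; a higher number here means a larger maximal response, a lower number a smaller maximal response. In this assay compound 1 gives 80%, the highest of the three numbers measured, though compound 2 lies within the scatter of it. Compound 2 `CC#C[C@@H](CC(=O)O)c1ccc(OC[C@H]2COc3ccccc3O2)cc1` carries hydrogen where compound 1 carries chloro, and in this assay compound 2 gives 70%; the change is a number 10 percentage points lower from compound 1 to compound 2 (within the scatter). Compound 3 `CC#C[C@@H](CC(=O)O)c1ccc(OC[C@H]2COc3ccc(C(=O)N(C)C)cc3O2)cc1` carries a dimethylcarbamoyl group where compound 2 carries hydrogen, and in this assay compound 3 gives 32%; that change is a number 38 percentage points lower from compound 2 to compound 3 (beyond the scatter), so compound 3 sits well below compound 1.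

Compound 4 `CC#C[C@@H](CC(=O)O)c1ccc(OC[C@H]2COc3cc(Cl)c(Cl)cc3O2)cc1` differs from compound 1 in one place: chloro in place of hydrogen on an aromatic carbon. The new chloro sits ortho to the chloro group already present. The step from compound 1 to compound 2 bears most directly on this change, since it concerns the same kind of group on the same ring, and it stayed within the scatter. Among the measured compounds shown here, no measured compound here carries a second chloro, so the expectation rests on that single step. A change no larger than the scatter is therefore expected, a number 2 percentage points lower from compound 1 to compound 4 (within the scatter). Compound 4 is expected to give about 78% in this assay, between 60% and 95%.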

Compound 4, largest response reached (Emax), in percent of the reference or control that the assay uses: 33%
Compound 4: the middle estimate sits 45 percentage points above what was measured; measured number below the stated range.
By their numbers in this assay, from the lowest: compounds 3 and 4 (each within the scatter of the next); then compounds 2 and 1 (each within the scatter of the next).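

In this assay the added chloro brings a number 47 percentage points lower from compound 1 to compound 4 (beyond the scatter) and thus a large fall, so a group of a single heavy atom on this aromatic carbon, ortho to a chloro group, is enough to cut the maximal response sharply. The earlier chloro step, a number 10 percentage points lower from compound 1 to compound 2 (within the scatter) and so no change beyond the scatter, gave no sign of this, which means the result of a chloro on one carbon of this ring cannot be carried over to another carbon of the same ring. Among the compounds shown here, a large step had so far come only with the dimethylcarbamoyl group, as a number 38 percentage points lower from compound 2 to compound 3 (beyond the scatter) shows, and now a lone chloro also produces one.

Nothing available here explains why the response falls at this position. From the compounds shown here alone, it remains open whether fluoro, methyl or methoxy on this same carbon would lower the response as far, and whether chloro here would do so in a compound lacking the first chloro.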